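Extending the chain amine through a sulfur link

The source may hold more compounds than are shown below. What is called first, only, known or untested is meant among the compounds shown, and "the series" means these compounds.

Compound 1 `NCCCCc1c[nH]c2c(F)cccc12` gives 21 nM in an assay on isolated protein for inhibition of Myeloperoxidase (Homo sapiens), read by ELISA, with a stated time of 5 min (on this read-out lower numbers stand for stronger inhibition and higher numbers for weaker inhibition), the lowest of the two numbers at hand; compound 3 `N#CSCCCc1c[nH]c2ccc(F)cc12` sits within the scatter of it at 23 nM. Compound 2 `CCCc1c[nH]c2ccc(F)cc12` is reported only as a limit of the assay, > 100 nM, which is the limit of > 100 nM in this assay, at which 1 of the 3 values shown sits. For the measured compounds named here, the one single-point step measured so far, an at least 4.3-fold lower number from compound 2 to compound 3 (0.63 log units; beyond the scatter), shows that a sulfur-bearing group at that chain carbon is well tolerated and lifts the number out of the limit into the range where compound 1 also stands.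

Compound 4 `NCCSCCCc1c[nH]c2c(F)cccc12` differs from compound 1 by (2-aminoethyl)sulfanyl in place of aminomethyl on a saturated chain carbon, three bonds along the chain from an aromatic carbon. The change keeps the terminal amine of compound 1 and inserts a sulfur at the same chain carbon where compound 3 carries its cyanosulfanyl; the step from compound 2 to compound 3 bears on it only in showing that sulfur at this place does no harm, since compound 1 and compound 3 give numbers within the scatter of each other. Going by the values given here, no step adds to the chain length beyond that, so a move beyond the scatter in either direction is not expected. Compound 4 is estimated at 20 nM, between 8 nM and 60 nM, an expected step of a 1.1-fold lower number from compound 1 to compound 4 (0.02 log units; within the scatter).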

Compound 4, half-maximal inhibitory concentration: > 100 nM
Compound 4: only a limit was reported; the forecaster's own chance of this, stated with the estimate: 5%; middle value at least 5.0-fold (0.69 log units) away from the limit.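

The change gives an at least 4.7-fold higher number from compound 1 to compound 4 (0.67 log units; beyond the scatter) in this assay, so on the core of compound 1, (2-aminoethyl)sulfanyl in place of aminomethyl on a saturated chain carbon, three bonds along the chain from an aromatic carbon, is not tolerated, even though the terminal amine is kept. The earlier step, an at least 4.3-fold lower number from compound 2 to compound 3 (0.63 log units; beyond the scatter), was read on a different core and with cyanosulfanyl, and this result shows that it gives no general licence for a sulfur-bearing group at this place. Compound 4 is reported only as a limit, and compound 2 is the other compound reported that way, so the two cannot be ranked against each other: the limit of > 100 nM in this assay, at which 2 of the 4 values shown sit.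

The compounds shown leave open whether the loss follows the sulfur itself or the longer chain, and a longer all-carbon chain ending in an amine on the core of compound 1 would separate the two. They also leave open whether a sulfone or an ether oxygen in place of the sulfur, or a shorter aminomethyl sulfanyl chain, would stay with compound 1 or fall with compound 4.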